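This account rests on a few compounds, and the source may have more. Where it says the series, first, only, none or still open, it means among the compounds named here.

Of the compounds shown here, two have been tested so far in an ADME assay on HEK293 cells (Homo sapiens) for cytotoxicity, with a stated time of 6 h (a higher number here means that more compound is tolerated, a lower number that less compound is tolerated), and neither gives an exact number. Compound 1 `CCCCNc1nc(N)nc2cc(OC)ccc12` reads > 18000 nM, which is a limit of the assay. Compound 2 `CCCCNc1nc(N)nc2cccc(CC3CCCC3)c12` reads > 25000 nM, which is also a limit, and this is all that is known of where compound 2 stands. Compound 3 `CCCCNc1nc(N)nc2cccc(C(=O)NC)c12` has methylcarbamoyl in place of cyclopentylmethyl on an aromatic carbon. Going by the values given here, no two measured compounds differ in one place only, so no measured step is available as a guide. With compound 2 known only as the limit > 25000 nM, no step beyond the usual scatter is expected in this assay, in either direction. The estimated step is a step that the limit leaves unreadable from compound 2 to compound 3. For compound 3 the expected value is 30000 nM, with an estimated range of 15000 nM to 60000 nM.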

Compound 3, half-maximal cytotoxic concentration: > 25000 nM
Compound 3 was reported as a limit; the forecaster's own chance of this, stated with the estimate: 85%; the middle value lies beyond the limit too.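

No step can be read between compound 2 and compound 3 in this assay, because each is reported only as a limit: the limit of > 25000 nM in this assay, at which 2 of the 3 values shown sit.

The compounds shown leave open at what concentration each harms these cells, and whether methylcarbamoyl in place of cyclopentylmethyl changes that concentration.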